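The compounds below may be only part of what the source reports. "The series", "measured", "known", "first", "only" and "open" are said of these compounds alone.

Working notes on the series. Compound 1 `CCc1ccc(N(CC(C)C)S(=O)(=O)c2ccc3c(c2)C(OC2CCCCC2)CC(C2CCOCC2)O3)cc1` and compound 2 `CCc1ccc(N(CC2CCC2)S(=O)(=O)c2ccc3c(c2)C(O)CC(C2CCOCC2)O3)cc1` share a core; in a physicochemical assay for lipophilicity, at pH 7.4 (a higher number here means a more lipophilic compound, a lower number a more polar compound), compound 1 gives 6.28, and compound 2 gives 4.01, the lower of the two numbers by a margin well beyond the scatter. The step to compound 3 `CCc1ccc(N(Cc2ccccc2)S(=O)(=O)c2ccc3c(c2)C(O)CC(C2CCOCC2)O3)cc1` is the exchange (phenyl in place of cyclobutyl on a saturated chain carbon bound to a sulfonamide nitrogen). Within the data shown here, no measured pair isolates this change, so the expected step from cyclobutylmethyl to benzyl in this assay rests on general ring-for-ring behaviour: a small rise, likely near the edge of the scatter, so that a number 0.24 log units higher from compound 2 to compound 3 (within the scatter) is expected. Compound 3 is thus estimated at 4.25 in this assay, between 3.85 and 4.65.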

Compound 3, distribution coefficient: 4.68
Compound 3: the middle estimate sits 0.43 log units below what was measured; measured number above the stated range.
By their numbers in this assay, from the lowest: compound 2; then compound 3; then compound 1.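

In this assay, among these compounds, the exchange of cyclobutylmethyl for benzyl gives a number 0.67 log units higher from compound 2 to compound 3 (beyond the scatter) and is the first step that can be read at a single place. With the rest of the structure unchanged, a change of ring alone on a saturated chain carbon bound to a sulfonamide nitrogen moves this read-out beyond the scatter. Nothing at hand accounts for the size of the step. Open, as far as these compounds go, is how phenethyl in place of benzyl would read in this assay. Also open, from the compounds shown here alone, is how a benzyl carrying an amine or a carboxylic acid would read.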